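The compounds below may be only part of what the source reports. "The series", "measured", "known", "first", "only" and "open" are said of these compounds alone.

Compound 1 `CC(C)[C@@H]1CC[C@@H](C)C[C@@]12N(C)C(=O)[C@@H]1[C@H]3C(=O)N(c4ccccc4)C(=O)[C@H]3ON12` stands highest of the three compounds measured in a functional assay, with a stated time of 20 min, tested at 2 mg/mL; on this read-out lower numbers stand for a weaker effect and higher numbers for a stronger effect at the one concentration tested; there compound 1 gives 74.2%. Compound 2 `COc1ccc(N2C(=O)[C@H]3[C@H](ON4[C@@H]3C(=O)N(C)[C@@]43C[C@H](C)CC[C@H]3C(C)C)C2=O)cc1` gives 61.7% and compound 3 `Cc1cccc(N2C(=O)[C@H]3[C@H](ON4[C@@H]3C(=O)N(C)[C@@]43C[C@H](C)CC[C@H]3C(C)C)C2=O)c1` gives 49.9%. Both measured changes on the aryl group lower the number: a number 12.5 percentage points lower from compound 1 to compound 2 (beyond the scatter) and a number 24.3 percentage points lower from compound 1 to compound 3 (beyond the scatter), with a number 11.8 percentage points lower from compound 2 to compound 3 (beyond the scatter) between those two. Compound 4 `CC(C)[C@@H]1CC[C@@H](C)C[C@@]12N(C)C(=O)[C@@H]1[C@H]3C(=O)N(c4ccc5ccccc5c4)C(=O)[C@H]3ON12` differs from compound 1 as follows: naphthalen-2-yl in place of phenyl on an amide-type nitrogen in a ring. Among the compounds with values here, no measured step exchanges the whole aryl group; the steps from compound 1 to compound 2 and to compound 3 are the nearest guide, each a modest loss. A modest decrease is therefore expected in this assay, a number 16.2 percentage points lower from compound 1 to compound 4 (beyond the scatter). For compound 4 the estimate is 58%, with a range from 35% to 78%.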

Compound 4, a percentage reported as activity, at one concentration (the size of the read-out at that concentration, not a potency): 35%
Estimate against measurement, compound 4: 23 percentage points above; measured number inside the range.
By their numbers in this assay, from the lowest: compound 4; then compound 3; then compound 2; then compound 1.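

At the aryl group on the amide-type nitrogen, naphthalen-2-yl gives the largest loss from phenyl seen in this assay (a number 39.2 percentage points lower from compound 1 to compound 4 (beyond the scatter)). Compound 4 also lies under both substituted phenyl compounds (a number 26.7 percentage points lower from compound 2 to compound 4 (beyond the scatter); a number 14.9 percentage points lower from compound 3 to compound 4 (beyond the scatter)), so all three replacements of phenyl shown here lower the number, and naphthalen-2-yl lowers it most. No data shown here explain this order.

Still open, going by these compounds, is whether any group here can match phenyl. A pyridinyl ring, a cyclohexyl ring or a benzyl group on this nitrogen would test that.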